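The source may hold more compounds than are shown below. What is called first, only, known or untested is meant among the compounds shown, and "the series" means these compounds.

Working notes on the series: in a functional assay (trachea) with Cavia porcellus as the target (a lower number here means a stronger inhibitor, a higher number a weaker inhibitor), compound 1 `Cn1nc(-c2cccnc2)c2ccccc2c1=O` gives 11500 nM, compound 2 `CCCCCCCCn1nc(-c2cccnc2)c2ccccc2c1=O` gives 21900 nM and compound 3 `O=c1c2ccccc2c(-c2cccnc2)nn1CCSc1ccccc1` gives 9120 nM. Compound 3 stands within the scatter of compound 1 and clear of compound 2. Compound 4 `O=C(O)c1ccc(Cn2nc(-c3cccnc3)c3ccccc3c2=O)cc1` has 4-carboxyphenyl in place of (phenylsulfanyl)methyl on a saturated chain carbon bound to an aromatic nitrogen. The steps bearing on this change are a 1.3-fold lower number from compound 1 to compound 3 (0.10 log units; within the scatter), a 1.9-fold higher number from compound 1 to compound 2 (0.28 log units; within the scatter) and a 2.4-fold lower number from compound 2 to compound 3 (0.38 log units; beyond the scatter). Among the compounds with values here, all are small, but no measured compound carries a 4-carboxyphenyl group, so the guide is indirect. No step beyond the scatter is therefore expected in this assay. The expected step is a 1.3-fold higher number from compound 3 to compound 4 (0.12 log units; within the scatter). For compound 4 the estimate is 12000 nM, with an expected range of 4000 nM to 36000 nM.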

Compound 4, half-maximal inhibitory concentration: 17000 nM
Estimate against measurement, compound 4: 1.4-fold (0.15 log units) below; the range from low to high includes it.
By their numbers in this assay, from the lowest: compounds 3, 1, 4 and 2 (each within the scatter of the next, the first and the last beyond it).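

In this assay the 4-carboxyphenyl group, the first at this place with a hydrogen-bond donor, gives only steps within the scatter: a 1.9-fold higher number from compound 3 to compound 4 (0.27 log units; within the scatter) and a 1.3-fold lower number from compound 2 to compound 4 (0.11 log units; within the scatter) and a 1.5-fold higher number from compound 1 to compound 4 (0.17 log units; within the scatter) are all that it changes. Unlike the earlier compounds, compound 4 shows that a carboxylic acid on this saturated chain carbon bound to an aromatic nitrogen leaves the number beyond the scatter of none of the other three compounds. Nothing at hand accounts for these steps. From the compounds shown here alone, whether an amine or a primary amide at this place would give a step beyond the scatter remains open.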